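Cyclopropyl for Cyano in a Liver Microsome Stability Series

This account rests on a few compounds, and the source may have more. Where it says the series, first, only, none or still open, it means among the compounds named here.

Compound 1 (`Cc1nc(N2CCN(C)CC2)c2nc(-c3cccc(C(F)(F)F)c3)n(C3CCOCC3)c2n1`) and compound 2 (`Cc1nc(N2CCN(C)CC2)c2nc(-c3ccccc3C#N)n(C3CCOCC3)c2n1`) share one core and differ only in the substituted phenyl group attached to it. In an ADME assay (liver) for metabolic stability, with Liver microsome (Homo sapiens) as the target, read by LC-MS, using microsomes, with a stated time of 30 min, tested at 4 uM (on this read-out higher numbers stand for a more stable compound and lower numbers for a less stable compound), compound 1 gives 19% of the compound remaining, and compound 2 gives 20% in the same test. Within the data shown here, these two values lie within the scatter of each other, so compound 2 stands level with the only other measured compound.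

Compound 3 (`Cc1nc(N2CCN(C)CC2)c2nc(-c3ccccc3C3CC3)n(C3CCOCC3)c2n1`) carries cyclopropyl in place of cyano on an aromatic carbon and otherwise matches compound 2. Among the measured compounds shown here, only one measured step can serve as a guide, and it is a different swap: 2-cyanophenyl in place of 3-(trifluoromethyl)phenyl gave a number 1 percentage points higher from compound 1 to compound 2 (within the scatter) and so moved nothing beyond the scatter. For the measured compounds named here, no measurement yet shows how cyclopropyl behaves, which makes the guide a weak one. Taking the value of compound 2 as the anchor, the expected change is a number 2 percentage points lower from compound 2 to compound 3 (within the scatter) and no real shift in either direction is anticipated. Compound 3 is expected to give 18% with an estimated range from 7% to 32% once tested in this assay as well.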

Compound 3, percent of the compound remaining: 33%
The estimate for compound 3 lay 15 percentage points below the measured number; measured number above the stated range.
By their numbers in this assay, from the lowest: compounds 1 and 2 (each within the scatter of the next); then compound 3.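

In this assay, the swap of 2-cyanophenyl for 2-cyclopropylphenyl gives a number 13 percentage points higher from compound 2 to compound 3 (beyond the scatter) and so, unlike the earlier step between the two first compounds, it moves the number beyond the scatter; this shows that the group on this aromatic carbon, ortho to a large group, can change the read-out, even if the gain is modest. The other step, a number 14 percentage points higher from compound 1 to compound 3 (beyond the scatter), is of similar size and also lies beyond the scatter, so compound 3 stands clear of both earlier compounds, which remain level with each other. Nothing measured for these compounds bears on why the number rose.

The compounds shown cannot separate a gain tied to the three-membered ring itself from a gain that any small carbon group at this place might bring, and a methyl or an isopropyl group would be the direct test of that. From the compounds shown here alone, it also remains open whether the change would carry over to the same place when another part of the shared core is altered, for example when the tetrahydropyranyl group gives way to a simple amine.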